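A few compounds are considered here, and "the series" means these few. Any claim that something is new, unique, unknown or untested is made for them only; others in the source may bear on it.

Measured compounds in a functional assay on MDA-MB-468 cells (Homo sapiens) for cytotoxicity, with a stated time of 48 h; a lower number here means a stronger inhibitor, a higher number a weaker inhibitor:
compound 1 `O=[N+]([O-])c1ccc(CN2CCC(n3cc(CC(OCc4cc(-c5ccccc5)no4)c4ccc(Br)cc4)nn3)CC2)cc1` — 3000 nM
compound 2 `N#Cc1ccc(-c2cc(COC(Cc3cn(C4CCN(Cc5ccc([N+](=O)[O-])cc5)CC4)nn3)c3ccc(Br)cc3)on2)cc1` — 5000 nM
compound 3 `O=[N+]([O-])c1ccc(CN2CCC(n3cc(CC(OCc4cc(-c5cccc(Br)c5)no4)c4ccc(Br)cc4)nn3)CC2)cc1` — a limit only, > 25000 nM

Compound 1 and compound 2 sit close together in this assay; the change a 1.7-fold higher number from compound 1 to compound 2 (0.22 log units; within the scatter) stays within the scatter. Compound 3 stands apart: this assay reports for it only a limit, (the limit of > 25000 nM in this assay, at which 1 of the 3 values shown sits), and not a number. Its steps from the other two, an at least 8.3-fold higher number from compound 1 to compound 3 (0.92 log units; beyond the scatter) and an at least 5.0-fold higher number from compound 2 to compound 3 (0.69 log units; beyond the scatter), are both beyond the scatter, so compound 3 is the weakest of the three as far as the numbers go, though how far beyond the limit it lies is not known.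

Compound 4 `O=[N+]([O-])c1ccc(CN2CCC(n3cc(CC(OCc4cc(-c5cccc(F)c5)no4)c4ccc(Br)cc4)nn3)CC2)cc1` is the next member. Relative to compound 3 it carries fluoro in place of bromo on an aromatic carbon. Among the compounds with values here, no measured step covers fluoro at this position. Within the data shown here, the steps that bear on it are an at least 8.3-fold higher number from compound 1 to compound 3 (0.92 log units; beyond the scatter), where bromo entering at this carbon raised the number, and an at least 5.0-fold higher number from compound 2 to compound 3 (0.69 log units; beyond the scatter). Removing the bromo is therefore expected to bring the number back down, but since compound 3 is known only as a limit, the size of the step is uncertain. Compound 4 is expected to land around 8000 nM, within 2500 nM to 25000 nM, a step of an at least 3.1-fold lower number from compound 3 to compound 4 (0.49 log units; beyond the scatter) from compound 3, with a real chance that this assay again returns only a limit.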

Compound 4, half-maximal inhibitory concentration: 3000 nM
The estimate for compound 4 lay 2.7-fold (0.43 log units) above the measured number; measured number inside the range.
By their numbers in this assay, from the lowest: compounds 1, 4 and 2 (each within the scatter of the next). At a limit, above all of these: compound 3.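

In this assay, the loss seen with compound 3 does not extend to every halogen at this carbon: fluoro in place of bromo gives an at least 8.3-fold lower number from compound 3 to compound 4 (0.92 log units; beyond the scatter), and fluoro in place of hydrogen gives no change at the digits printed from compound 1 to compound 4 (within the scatter). The 3-fluorophenyl and 4-cyanophenyl groups are not separated either, with a 1.7-fold lower number from compound 2 to compound 4 (0.22 log units; within the scatter), so three of the four compounds now form a group within the scatter of one another, and only the bromo compound stands apart. The step from bromo to fluoro can be read in one direction only, as compound 3 is a limit and not a number: the limit of > 25000 nM in this assay, at which 1 of the 4 values shown sits.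

The compounds shown place only hydrogen, fluoro and bromo on this carbon, so it remains open whether chloro, methyl or methoxy would follow fluoro or bromo here. Also open, going by these compounds, is whether the loss belongs to bromo at this carbon specifically or would recur with bromo in the place that the nitrile occupies in compound 2, and whether an amine or a carboxylic acid on this ring would be accepted.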